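Nitrile to Trifluoromethyl on a Weak Transporter Inhibitor

The source may hold more compounds than are shown below. What is called first, only, known or untested is meant among the compounds shown, and "the series" means these compounds.

In an assay on tissue (RPTEC cells) for inhibition of solute carrier family 22 member 12 (Homo sapiens), read by scintillation counting, with stated times of 15 min and 2 h (on this read-out lower numbers stand for stronger inhibition and higher numbers for weaker inhibition), compound 1 `N#Cc1cc(C(=O)N2CCc3ccccc32)cc(C#N)c1O` gives 83900 nM.
In this assay compound 2 `N#Cc1cc(C(=O)N2CCc3ccccc32)cc(C(F)(F)F)c1O` gives > 100000 nM, which is a limit of the assay rather than a number.
In this assay compound 3 `N#Cc1cc(C(=O)N2CS(=O)(=O)c3ccccc32)cc(Cl)c1O` gives > 100000 nM, also a limit of the assay.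

All three share a hydroxylated aromatic ring joined through a carbonyl to a second ring system; how the core of compound 1 and the core of compound 3 differ is not broken down here. From compound 1 to compound 2 the change is trifluoromethyl in place of cyano on an aromatic carbon, and it produced an at least 1.1-fold higher number from compound 1 to compound 2 (0.07 log units; that floor lies within the scatter). This step is capped by the limit of > 100000 nM in this assay, at which 2 of the 3 values shown sit.

Compound 4 `O=C(c1cc(Cl)c(O)c(C(F)(F)F)c1)N1CS(=O)(=O)c2ccccc21` is not yet measured. It arises from compound 3 by the same kind of change, (trifluoromethyl in place of cyano on an aromatic carbon); the surroundings differ in that the group meta to the changed carbon is a chloro group rather than a cyano group. Compound 3 itself already stands at a limit of the assay. Given the earlier step of an at least 1.1-fold higher number from compound 1 to compound 2 (0.07 log units; that floor lies within the scatter), compound 4 is expected to give 200000 nM, between 100000 nM and 600000 nM, most likely again reported only as a limit. The expected step is a step that the limit leaves unreadable from compound 3 to compound 4.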

Compound 4, half-maximal inhibitory concentration: 2600 nM
The estimate for compound 4 lay 77-fold (1.89 log units) above the measured number, outside the stated range (below it).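

Trifluoromethyl in place of cyano in this assay gave an at least 38-fold lower number from compound 3 to compound 4 (1.58 log units; beyond the scatter), so the result on one core did not carry over to the other: the same change on two cores in this assay, an at least 1.1-fold higher number (0.07 log units; that floor lies within the scatter) from compound 1 to compound 2 and an at least 38-fold lower number (1.58 log units; beyond the scatter) from compound 3 to compound 4, at least 45-fold (1.66 log units) apart, beyond the scatter of two such steps

Each of the two steps touches a limit of the assay, so only its floor can be read, not its full size: the limit of > 100000 nM in this assay, at which 2 of the 4 values shown sit.

These two pairs show that the same swap need not give the same result in this series, but they give no general rule, and compound 1 and compound 3 differ in more than one place, so the data cannot say which difference matters.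

Going by these compounds, it remains open whether the chloro group or the rest of the core of compound 3 decides the outcome, a question that a compound joining the core of compound 1 to a chloro group would address. On these data alone, it is also open whether another group on the same aromatic carbon, such as a methyl group or a carboxylic acid, would match trifluoromethyl on the core of compound 4.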